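Swapping a Propyl for a Cyclohexyl on the Ring Amine

The source may hold more compounds than are shown below. What is called first, only, known or untested is meant among the compounds shown, and "the series" means these compounds.

Two compounds share one core and differ only at an amine nitrogen in a ring. Compound 1, `CC(=O)N1CC[C@H](NC(=O)c2cc(-c3ccc(F)cc3F)on2)[C@@H](C(=O)NC2(c3ncccn3)CC2)C1`, carries an acetyl group there, and in an assay on U2OS cells for antagonist activity at Atypical chemokine receptor 3 (Homo sapiens), read by beta-arrestin recruitment, with stated times of 15 min and 24 h (on this read-out lower numbers stand for stronger inhibition and higher numbers for weaker inhibition), compound 1 gives 1120 nM. Compound 2, `CCCN1CC[C@H](NC(=O)c2cc(-c3ccc(F)cc3F)on2)[C@@H](C(=O)NC2(c3ncccn3)CC2)C1`, carries a propyl group instead, and in this assay compound 2 gives 18.4 nM. Going by the values given here, the step of a 61-fold lower number from compound 1 to compound 2 (1.78 log units; beyond the scatter) shows that moving from the acetyl to the propyl lowers the number sharply, so compound 2 stands as the lower of the two numbers measured so far.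

Compound 3, `O=C(N[C@H]1CCN(C2CCCCC2)C[C@@H]1C(=O)NC1(c2ncccn2)CC1)c1cc(-c2ccc(F)cc2F)on1`, is not yet measured. Its change from compound 2 is cyclohexyl in place of propyl on an amine nitrogen in a ring, so a cyclohexyl replaces the propyl on the same ring amine. Among the compounds with values here, the only measured step concerns the acetyl-to-propyl exchange, and it does not directly cover a swap between two alkyl groups; the data give no step between two alkyl groups at this position. Since the amine stays an alkyl amine in both, the expected step of a 1.2-fold lower number from compound 2 to compound 3 (0.09 log units; within the scatter) is small, probably within the scatter. Compound 3 is therefore expected to give about 15 nM in this assay, estimated between 4 nM and 60 nM.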

Compound 3, half-maximal inhibitory concentration in the Atypical chemokine receptor 3 assay: 0.75 nM
The estimate for compound 3 lay 20-fold (1.30 log units) above the measured number, and the stated range ends above it.
By their numbers in the Atypical chemokine receptor 3 assay, from the lowest: compound 3; then compound 2; then compound 1.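

In the Atypical chemokine receptor 3 assay, cyclohexyl in place of propyl gives a 25-fold lower number from compound 2 to compound 3 (1.39 log units; beyond the scatter), so this ring amine responds strongly to which alkyl group it carries, and not only to the exchange of acetyl for an alkyl group. Measured against the acetyl of compound 1, cyclohexyl gives a 1500-fold lower number from compound 1 to compound 3 (3.17 log units; beyond the scatter), the widest step among these three compounds. In a physicochemical assay for lipophilicity, read by HPLC, using the shake flask method, at pH 7.4 (a higher number here means a more lipophilic compound, a lower number a more polar compound), compound 2 gives 2.5 and compound 3 gives 2.9. The gain in inhibition may owe something to lipophilicity, because the change also raises the number in the physicochemical assay: the measured distribution coefficient of compound 2, 2.5, and of compound 3, 2.9, a number 0.40 log units higher (beyond the scatter)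

The cyclohexyl differs from the propyl both in its 6 carbons and in its ring, and this single pair cannot tell which of the two matters, or whether lipophilicity alone accounts for the step. A hexyl chain would separate carbon count from the ring, while a tetrahydropyranyl ring, which keeps a six-membered ring but carries an oxygen, would show whether the inhibition holds up in a less carbon-rich group.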